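A Bromophenyl Exchange on the Most Potent Arylthio Enone

A few compounds are considered here, and "the series" means these few. Any claim that something is new, unique, unknown or untested is made for them only; others in the source may bear on it.

Of the three compounds measured in a functional assay on DU-145 cells (Homo sapiens) for inhibition, read by trypan blue exclusion, with a stated time of 96 h (a higher number here means a weaker inhibitor of growth, a lower number a stronger inhibitor of growth), compound 1 `COc1ccc(/C=C(/Sc2ccc(C)cc2)C(=O)c2ccc(Cl)cc2)cc1O` gives 1000 nM and stands lowest; the steps to both other compounds lie beyond the usual scatter. Compound 2 `Cc1ccsc1/C=C(/SCc1ccc(F)cc1)C(=O)c1ccc(Br)cc1` gives 50000 nM in this assay, and compound 3 `O=C(/C(=C\c1c(O)cc(O)cc1O)S(=O)(=O)c1ccccc1Br)c1ccc(Cl)cc1` gives 50000 nM in this assay. Among the measured compounds shown here, both of these differ from compound 1 in several places at once, so no single step between measured compounds is available to guide the change now considered.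

Compound 4 `Cc1ccc(S/C(=C/c2ccc(Br)cc2)C(=O)c2ccc(Cl)cc2)cc1` differs from compound 1 in one place: 4-bromophenyl in place of 3-hydroxy-4-methoxyphenyl on a double-bonded chain carbon bound to a double-bonded chain carbon. Without a measured step of this kind, the expected change from compound 1 to compound 4 in this assay is uncertain; a moderate weakening is expected, though a result within the scatter of compound 1 cannot be excluded. The estimated step is a 3.0-fold higher number from compound 1 to compound 4 (0.48 log units; beyond the scatter). Compound 4 is therefore expected to give about 3000 nM in this assay, with a range from 500 nM to 20000 nM.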

Compound 4, concentration for 50% growth inhibition: 25000 nM
Compound 4: middle estimate off by 8.3-fold (0.92 log units), on the low side; the measured number lies above the stated range.
By their numbers in this assay, from the lowest: compound 1; then compounds 4, 2 and 3 (each within the scatter of the next).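

In this assay, among the compounds shown here, 4-bromophenyl in place of 3-hydroxy-4-methoxyphenyl on a double-bonded chain carbon bound to a double-bonded chain carbon gives a 25-fold higher number from compound 1 to compound 4 (1.40 log units; beyond the scatter), the first step in this set that changes one place only. The rest of compound 1 stays the same, so this position is shown to be far from indifferent to the group it carries: the group that leaves has 1 hydrogen-bond donor and 2 hydrogen-bond acceptors, and the group that enters has neither. No measurement available here explains the size of this step.

The hydroxy and the methoxy leave together in this one exchange, so their separate shares in the step remain unresolved. Also open, from the compounds shown here alone, is how a phenyl carrying an amine or a carboxylic acid at this position would compare with compound 1.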